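A few compounds are considered here, and "the series" means these few. Any claim that something is new, unique, unknown or untested is made for them only; others in the source may bear on it.

The study sets four compounds on a shared core side by side. Compound 1 has the structure `CCC(CC)O[C@@H]1C=C(C(=O)O)C[C@H](NCc2ccc(SC3CCCC3)cc2)[C@H]1NC(C)=O`. Compound 2, `CCC(CC)O[C@@H]1C=C(C(=O)O)C[C@H](NCc2cccc(SC3CCCC3)c2)[C@H]1NC(C)=O`, is built from the same atoms joined differently, and the difference between the two cores is not broken down here. Compound 3 is `CCC(CC)O[C@@H]1C=C(C(=O)O)C[C@H](NCc2ccc(-c3ccc(SC)cc3)cc2)[C@H]1NC(C)=O`, and compound 4, which has not yet been measured, is `CCC(CC)O[C@@H]1C=C(C(=O)O)C[C@H](NCc2cccc(-c3ccc(SC)cc3)c2)[C@H]1NC(C)=O`.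

In an ADME assay on cells (Fibroblast, Gallus gallus) for cytotoxicity, read by CCK-8 assay, with a stated time of 48 h (on this read-out lower numbers stand for higher toxicity in this test and higher numbers for lower toxicity in this test), compound 1 reaches only a limit of the test, > 200000 nM. Compound 2 likewise gives only a limit in this assay, > 200000 nM. For compound 3 the result in this assay is again a limit, > 200000 nM. The step that the two limits leave unreadable from compound 1 to compound 3 is therefore one whose size cannot be read; the change behind it is 4-(methylsulfanyl)phenyl in place of cyclopentylsulfanyl on an aromatic carbon, made para to a large group. Compound 4 arises from compound 2 by the same kind of change, (4-(methylsulfanyl)phenyl in place of cyclopentylsulfanyl on an aromatic carbon), here made meta to a large group.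

Everything known so far rests on (the limit of > 200000 nM in this assay, at which 3 of the 3 values shown sit). Because the limit of > 200000 nM in this assay, at which 3 of the 3 values shown sit, is where every value sits, no reading of the change is possible, and compound 4 is expected to behave like the others. The expected step is a step that the limit leaves unreadable from compound 2 to compound 4, set beside a step that the two limits leave unreadable from compound 1 to compound 3, and it is an estimate only. Compound 4 is thus expected to show 300000 nM in this assay, most likely reported as a further limit, with an estimated range from 150000 nM to 1000000 nM.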

Compound 4, half-maximal cytotoxic concentration: > 200000 nM
Compound 4: only a limit was reported (the forecaster's own chance of this, stated with the estimate: 90%); the middle value lies beyond the limit too.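

In this assay, within the data shown here, compound 4 also gives only a limit, > 200000 nM, so the step from compound 2 to compound 4 cannot be read, any more than the one from compound 1 to compound 3: the limit of > 200000 nM in this assay, at which 4 of the 4 values shown sit. The compounds shown leave open whether 4-(methylsulfanyl)phenyl in place of cyclopentylsulfanyl has any effect on the read-out of this assay, on either core.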